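Cytotoxicity Across Three Analogues and an Untested Fourth

The source may report more compounds than this note shows. Statements on the series, on what has been measured and on what is new or still open speak of the compounds shown alone.

Compound 1 `Cc1nc(-c2cccnc2)sc1-c1nnc(Cc2ccccc2)o1`, compound 2 `Cc1nc(-c2cccnc2)sc1-c1nnc(-c2ccccc2)o1` and compound 3 `Cc1nc(-c2cccnc2)sc1-c1nnc(-c2cccc(Cl)c2Cl)o1` share one core and differ in one place. In an ADME assay on HeLa cells (Homo sapiens) for cytotoxicity, read by MTT assay (on this read-out lower numbers stand for higher toxicity in this test and higher numbers for lower toxicity in this test), compound 1 gives > 100 ug/mL, which is a limit of the assay rather than a number. In this assay compound 2 gives > 100 ug/mL, again a limit. In this assay compound 3 likewise gives > 100 ug/mL, a limit, so compound 3 sits where every value here sits, at the limit of > 100 ug/mL in this assay, at which 3 of the 3 values shown sit. The steps a step that the two limits leave unreadable from compound 1 to compound 2, a step that the two limits leave unreadable from compound 1 to compound 3 and a step that the two limits leave unreadable from compound 2 to compound 3 cannot be sized. Compound 4 `Cc1ccccc1-c1nnc(-c2sc(-c3cccnc3)nc2C)o1` carries the change (2-methylphenyl in place of 2,3-dichlorophenyl on an aromatic carbon). For the measured compounds named here, because all three values sit at the limit of > 100 ug/mL in this assay, at which 3 of the 3 values shown sit, no measured step bearing on this change is readable, and in this assay compound 4 is expected to give 150 ug/mL, between 60 ug/mL and 400 ug/mL, a step that the limit leaves unreadable from compound 3 to compound 4 expected to stay within the scatter and most probably to be reported only as a limit.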

Compound 4, half-maximal cytotoxic concentration: > 100 ug/mL
Compound 4 ended at the assay's limit; the forecaster's own chance of this, stated with the estimate: 85%; the middle value lies beyond the limit too.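

With compound 4 also at a limit, its steps from compound 1, compound 2 and compound 3 cannot be read: the limit of > 100 ug/mL in this assay, at which 4 of the 4 values shown sit. The compounds shown leave open whether any change at this place alters the read-out in this assay.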